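This account rests on a few compounds, and the source may have more. Where it says the series, first, only, none or still open, it means among the compounds named here.

Measured so far:
compound 1, `Cc1c(OCCCCOc2ccc(C(=O)CC(C)(C)C)c(O)c2C)cccc1C(=O)O`, 109%
compound 2, `Cc1c(OCCCCOc2cccc(C(=O)O)c2)ccc(C(=O)CC(C)C)c1C`, 18.3%
compound 3, `Cc1c(OCCCCOc2ccccc2C(=O)O)ccc(C(=O)CC2CCCC2)c1O`, 32.9%

In an assay on HEK293 cells for positive allosteric modulation of metabotropic glutamate receptor 3 (Rattus norvegicus), read by thallium flux, with a stated time of 2.5 min (on this read-out higher numbers stand for larger maximal responses and lower numbers for smaller maximal responses), compound 1 stands highest of the three numbers; compound 3 sits lower by a gap beyond the scatter, and compound 2 lower still. Compound 4, `CC(=O)c1ccc(OCCCCOc2cccc(C(=O)O)c2C)c(C)c1O`, differs from compound 1 in one place: hydrogen in place of tert-butyl on a saturated chain carbon bound to a carbonyl carbon. Among the compounds with values here, no measured pair shows this change by itself, so the size of the step is open. Compounds 2 and 3, which differ from compound 1 in other places as well, both give lower values, so a drop beyond the scatter is expected for a number 64 percentage points lower from compound 1 to compound 4 (beyond the scatter). Compound 4 is therefore estimated to reach about 45%, with a likely range from 15% to 95%.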

Compound 4, largest response reached (reported as percent of maximum), in percent of the reference or control that the assay uses: 17.1%
The estimate for compound 4 lay 27.9 percentage points above the measured number; the measured number falls inside the stated range.
By their numbers in this assay, from the lowest: compounds 4 and 2 (each within the scatter of the next); then compound 3; then compound 1.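

In this assay, within the data shown here, replacing tert-butyl with hydrogen on the saturated chain carbon bound to a carbonyl carbon gives a large step, a number 91.9 percentage points lower from compound 1 to compound 4 (beyond the scatter), and this is the first change in a single place that can be read here. It shows that the maximal response depends strongly on what this position carries, as neopentylcarbonyl gives way to acetyl. Nothing measured here explains the drop. Still open, on these data alone, is whether an ethyl, a longer chain or a cyclopropyl on this carbon would retain the response of compound 1.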